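Swapping an Oxygen Bridge for Sulfur in a Diamine Core

The compounds below may be only part of what the source reports. "The series", "measured", "known", "first", "only" and "open" are said of these compounds alone.

Compound 1, `Nc1cc(N)c2nc(-c3ccccc3)c(Oc3ccc(Cl)c(Cl)c3)nc2c1`: in a functional assay on Malme-3M cells (Homo sapiens) for inhibition, read by sulforhodamine B assay, with a stated time of 48 h (on this read-out higher numbers stand for weaker inhibition of growth and lower numbers for stronger inhibition of growth), compound 1 gives 15800 nM.
Compound 2, `Nc1cc(N)c2nc(-c3ccccc3)c(NCc3ccc(Cl)c(Cl)c3)nc2c1`: compound 2 gives 3390 nM.
Compound 3, `CCOC(=O)[C@H](CCC(=O)O)NC(=O)c1ccc(Sc2nc3cc(N)cc(N)c3nc2-c2ccccc2)cc1`: compound 3 gives 19500 nM.

Among these three numbers, compound 1 stands second highest. Its nearest neighbour is compound 3, whose number is slightly higher but within the usual scatter, so the two cannot be told apart. Compound 2 shows a clearly lower number, a gap beyond the scatter, and so the stronger inhibition of growth of the set.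

Compound 4, `Nc1cc(N)c2nc(-c3ccccc3)c(Sc3ccc(Cl)c(Cl)c3)nc2c1`, has not yet been measured. It differs from compound 1 in a single place: (3,4-dichlorophenyl)sulfanyl in place of 3,4-dichlorophenoxy on an aromatic carbon. The shared core, the phenyl group and the two amino groups are all kept; only the bridging atom to the dichlorinated ring changes. Among the compounds with values here, no measured pair in this set differs in exactly this way, so there is no direct precedent for the step. Within the data shown here, the only other sulfur-bridged compound, compound 3, gives 19500 nM, close to compound 1, which suggests the bridge atom alone does not move the number much.

The step of a 1.3-fold lower number from compound 1 to compound 4 (0.12 log units; within the scatter) is therefore expected to be small, with no clear direction beyond the scatter. Compound 4 is estimated at 12000 nM, within a range from 4000 nM to 36000 nM.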

Compound 4, concentration for 50% growth inhibition: 19500 nM
Estimate against measurement, compound 4: 1.6-fold (0.21 log units) below, and the stated range covers the measured number.
By their numbers in this assay, from the lowest: compound 2; then compounds 1, 3 and 4 (each within the scatter of the next).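

Until this pair, the effect of the bridging atom at this position could only be inferred from compound 3, which also carries a very different side group, whereas compound 1 and compound 4 isolate that one atom. In this assay, placing (3,4-dichlorophenyl)sulfanyl instead of 3,4-dichlorophenoxy on the aromatic carbon next to the ring nitrogen gives a 1.2-fold higher number from compound 1 to compound 4 (0.09 log units; within the scatter), so the two compounds cannot be told apart, and in this pair sulfur and oxygen serve equally well as the link to the dichlorinated ring. Nothing in the available data bears on why the two compounds match.

From the compounds shown here alone, whether a sulfonyl bridge or a simple methylene bridge at this position would match them as well remains open, as does whether sulfur and oxygen would still match if a pyridine ring replaced the 3,4-dichlorophenyl ring. Going by these compounds, these results also come from one cell line, so it remains open whether compound 1 and compound 4 would stay this close in other cells.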